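The source may hold more compounds than are shown below. What is called first, only, known or untested is meant among the compounds shown, and "the series" means these compounds.

Two compounds bearing the same fused core carry this comparison. Compound 1 `COc1c(Cl)ccc2c1CCC2c1ncc[nH]1` gives, in a functional assay on CHO cells for agonist activity at Alpha-1A adrenergic receptor (Homo sapiens), read by FLIPR and calcium flux (on this read-out higher numbers stand for an effect only at larger amounts of compound and lower numbers for an effect already at smaller amounts), a value of 451 nM. Compound 2 `c1cc(-c2cn[nH]c2)c2c(c1)C(c1ncc[nH]1)CC2` gives in this assay a value of 14 nM, the lowest of the two numbers, with compound 1 standing a good way above it, well beyond the scatter. Within the data shown here, no step between two measured compounds that differ in one place is available, so the comparison rests on these two values alone.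

Compound 3 `Cn1ccc(-c2cccc3c2CCC3c2ncc[nH]2)n1` is the compound still to be measured. It differs from compound 2 by 1-methyl-1H-pyrazol-3-yl in place of 1H-pyrazol-4-yl on an aromatic carbon. Since the 1H-pyrazol-4-yl of compound 2 goes with the lower number 14 nM, the step in this assay from compound 2 to compound 3 is expected to be a modest rise, estimated as a 4.3-fold higher number from compound 2 to compound 3 (0.63 log units; beyond the scatter), a little beyond the scatter. Compound 3 is accordingly expected to give in this assay about 60 nM, within a range of 15 nM to 250 nM.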

Compound 3, half-maximal effective concentration: > 1300 nM
Compound 3 was reported as a limit; the forecaster's own chance of this, stated with the estimate: 5%; middle value at least 21-fold (1.33 log units) from the limit.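

Among these compounds, compound 3 gives the first step between two compounds that differ in one place, and it shows that activity in this assay depends strongly on the group at this aromatic carbon of the shared core: replacing 1H-pyrazol-4-yl with 1-methyl-1H-pyrazol-3-yl gives an at least 92-fold higher number from compound 2 to compound 3 (1.96 log units; beyond the scatter). A second five-membered aromatic ring with two hetero atoms is therefore not enough to keep the low number of compound 2. The value of compound 3 is a limit of the assay and not a number, so the step gives only a minimum size: the limit of > 1300 nM in this assay, at which 1 of the 3 values shown sits.

The change alters both the point of attachment and the methyl on nitrogen, and these two compounds cannot separate the two. As far as these compounds go, it remains open where 1-methyl-1H-pyrazol-4-yl or 1H-pyrazol-3-yl at this carbon would fall.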